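The compounds below may be only part of what the source reports. "The series", "measured", "known", "first", "only" and "open" are said of these compounds alone.

Measured compounds:
compound 1, `CC[C@H](C)[C@@H](CN(C(=O)[C@@H]1C[C@H]1c1ccccc1)c1ccc(-c2ccccc2)cc1)NC(C)=O`: 5.8 nM
compound 2, `NC1(CN(C(=O)[C@@H]2C[C@H]2c2ccccc2)c2ccc(-c3ccccc3)cc2)CCCC1`: 0.57 nM
compound 3, `CC(C)(N)CN(C(=O)[C@@H]1C[C@H]1c1ccccc1)c1ccc(-c2ccccc2)cc1`: 1.4 nM

In a functional assay for agonist activity at G protein-coupled receptor 88 (Homo sapiens), read by HTRF and cAMP accumulation (a lower number here means that less compound is needed, a higher number that more compound is needed for the effect), compound 3 holds the second highest of the three numbers: the step of a 2.5-fold higher number from compound 2 to compound 3 (0.39 log units; beyond the scatter) sets it apart from compound 2, while a 4.1-fold lower number from compound 1 to compound 3 (0.62 log units; beyond the scatter) sets it apart from compound 1. Compound 4, `O=C([C@@H]1C[C@H]1c1ccccc1)N(CC1CCCNC1)c1ccc(-c2ccccc2)cc1`, differs from compound 3 by piperidin-3-yl in place of 1-amino-1-methylethyl on a saturated chain carbon bound to an amide-type nitrogen. Going by the values given here, the steps that bear on this change are a 10-fold lower number from compound 1 to compound 2 (1.01 log units; beyond the scatter) and a 2.5-fold higher number from compound 2 to compound 3 (0.39 log units; beyond the scatter), both showing that a ring-bearing group with a free amine gives a lower number than the open 1-amino-1-methylethyl group. Compound 4 keeps a ring and a free amine, so a modest step downward, or none beyond the scatter, is expected, giving a 1.2-fold lower number from compound 3 to compound 4 (0.07 log units; within the scatter). Compound 4 is therefore estimated at 1.2 nM, with a range from 0.35 nM to 4.5 nM.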

Compound 4, half-maximal effective concentration: 10 nM
Compound 4: middle estimate off by 8.3-fold (0.92 log units), on the low side; measured number outside the range, above it.
By their numbers in this assay, from the lowest: compound 2; then compound 3; then compounds 1 and 4 (each within the scatter of the next).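

In this assay, a ring and a free amine together do not secure a low number at this place: piperidin-3-yl in place of 1-amino-1-methylethyl gives a 7.1-fold higher number from compound 3 to compound 4 (0.85 log units; beyond the scatter), and in place of 1-aminocyclopentyl it gives an 18-fold higher number from compound 2 to compound 4 (1.24 log units; beyond the scatter). Against the acetamido group of compound 1, the same ring gives a 1.7-fold higher number from compound 1 to compound 4 (0.24 log units; within the scatter), so the free amine of compound 4 does not set it apart from that compound. Nothing measured here gives a reason for these steps. Going by these compounds, whether pyrrolidin-3-yl or 1-aminocyclohexyl would stand nearer to compound 2 or to compound 4 remains open.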